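A few compounds are considered here, and "the series" means these few. Any claim that something is new, unique, unknown or untested is made for them only; others in the source may bear on it.

Series in a functional assay on DU-145 cells (Homo sapiens) for inhibition, read by trypan blue exclusion, with a stated time of 96 h; on this read-out lower numbers stand for stronger inhibition of growth and higher numbers for weaker inhibition of growth:
- compound 1 `Cc1ccc(CS/C(=C/c2c[nH]c3ccc(Br)cc23)C(=O)c2ccc(Cl)cc2)cc1`: 1000 nM
- compound 2 `CSc1ccc(/C=C(/SCc2ccc(C)cc2)C(=O)c2ccc(Cl)cc2)cc1`: 25000 nM
- compound 3 `CSc1ccc(/C=C(/SCc2ccc(C)cc2)C(=O)c2ccc(Br)cc2)cc1`: > 100000 nM (a limit of the assay, not a number)

Of the two actual numbers, compound 2 has the higher, and its nearest neighbour is compound 1. Compound 4 `Cc1ccc(CS/C(=C/c2cc(Cl)cc(Cl)c2)C(=O)c2ccc(Cl)cc2)cc1` changes compound 2 at one place: 3,5-dichlorophenyl in place of 4-(methylsulfanyl)phenyl on a double-bonded chain carbon bound to a double-bonded chain carbon. The new group sits on a double-bonded chain carbon bound to a double-bonded chain carbon.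

Going by the values given here, the closest precedent is a 25-fold higher number from compound 1 to compound 2 (1.40 log units; beyond the scatter), a large step at this same place. It shows that the place can move the number, but it involves a different group and gives no direction for compound 4. The second measured step, an at least 4.0-fold higher number from compound 2 to compound 3 (0.60 log units; beyond the scatter), is at least modest but lies at another place and bears only weakly.

No clear step beyond the scatter is therefore expected, though with wide uncertainty. The expected size is a 1.3-fold lower number from compound 2 to compound 4 (0.10 log units; within the scatter). The upper end of the expected range is set by the limit of > 100000 nM in this assay, at which 1 of the 3 values shown sits. For compound 4 the estimate is 20000 nM, with an expected range of 3000 nM to 100000 nM.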

Compound 4, concentration for 50% growth inhibition: 10000 nM
Estimate against measurement, compound 4: 2.0-fold (0.30 log units) above; low and high end bracket the measured number.
By their numbers in this assay, from the lowest: compound 1; then compound 4; then compound 2. At a limit, above all of these: compound 3.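

In this assay, a 2.5-fold lower number from compound 2 to compound 4 (0.40 log units; beyond the scatter) shows that replacing 4-(methylsulfanyl)phenyl with 3,5-dichlorophenyl, both single carbon-only aromatic rings, still moves the number at this place, and moves it lower. The 5-bromo-1H-indol-3-yl group keeps a clear lead over the new ring, with a 10-fold higher number from compound 1 to compound 4 (1.00 log units; beyond the scatter), so 3,5-dichlorophenyl recovers only part of the distance between compound 2 and compound 1. Nothing measured on these groups accounts for either step.

Going by these compounds, whether the lower number follows from the chlorine atoms themselves or from their placement stays open, as does the outcome with an amine or a carboxylic acid on this ring. On these data alone, compound 3 gives > 100000 nM, a limit of the assay and not a number, so the effect of bromo in place of chloro alongside 3,5-dichlorophenyl also stays open.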